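Bromo for nitro in the series: working notes

The source may report more compounds than this note shows. Statements on the series, on what has been measured and on what is new or still open speak of the compounds shown alone.

Compound 1 `COc1cc(OC)c(C(=O)/C=C/c2cnccn2)c(OC)c1` gives 693 nM
Compound 2 `COc1cc(OC)c(C(=O)/C=C/c2ccc(C(=O)O)cc2)c(OC)c1` gives 6230 nM
Compound 3 `O=C(/C=C/c1ccccc1)c1ccccc1[N+](=O)[O-]` gives 1520 nM

In a functional assay for inhibition, with Homo sapiens as the target (on this read-out lower numbers stand for stronger inhibition and higher numbers for weaker inhibition), compound 3 (1520 nM) holds the middle of the three numbers, with compound 1 lower and compound 2 higher, both gaps beyond the scatter. Compound 4 `O=C(/C=C/c1ccccc1)c1ccccc1Br` has bromo in place of nitro on an aromatic carbon, ortho to a large group (bromo in place of nitro on an aromatic carbon). Among the measured compounds shown here, no measured pair isolates this change, so the data give no size for it. Taking compound 3 (1520 nM) as the reference, no step beyond the scatter is expected in this assay in either direction. The expected step is a 1.0-fold lower number from compound 3 to compound 4 (0.01 log units; within the scatter) in this reading. For compound 4 the estimated value is 1500 nM (expected range 500 nM to 4500 nM).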

Compound 4, half-maximal inhibitory concentration: 1660 nM
Beside the measured number, compound 4's estimate is 1.1-fold (0.04 log units) below it; measured number inside the range.
By their numbers in this assay, from the lowest: compound 1; then compounds 3 and 4 (each within the scatter of the next); then compound 2.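

At this position, on an aromatic carbon ortho to a large group, bromo in place of nitro gives a 1.1-fold higher number from compound 3 to compound 4 (0.04 log units; within the scatter) in this assay. Among the compounds shown here, this is the first size for the change, and it lies within the scatter: three heavy atoms with hydrogen-bond acceptors leave, a single bromine without any enters, and the read-out does not separate the pair. No measurement at hand accounts for this result.

Going by these compounds, whether an amine or a carboxylic acid at this position would also read alike stays open. So does whether the same change holds on the core of compound 1, since only this one pair carries it.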